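The source may hold more compounds than are shown below. What is called first, only, known or untested is meant among the compounds shown, and "the series" means these compounds.

Of the compounds shown here, two have been measured in an assay on isolated protein for inhibition of alpha-galactosidase (Coffea arabica), tested at 1000 uM (a lower number here means less inhibition, a higher number more inhibition at the concentration tested (going by the name of the read-out)), so far. Compound 1, with the structure `C[C@]1(CO)NC[C@@H](O)[C@@H]1O`, carries a methyl group on its shared core and in this assay gives 0.6%. Compound 2, with the structure `OC[C@@]1(c2cccc(F)c2)NC[C@@H](O)[C@@H]1O`, carries a fluorine-bearing phenyl ring in the same place and in this assay gives 0%. Compound 2 thus stands at the bottom of the two numbers, but its gap to compound 1 is within the usual scatter, so the two cannot be told apart on these data.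

Compound 3, with the structure `OC[C@@]1(c2ccccc2)NC[C@@H](O)[C@@H]1O`, is not yet measured. Relative to compound 2 the change is hydrogen in place of fluoro on an aromatic carbon. Among the compounds with values here, no step between two measured compounds shows how this assay answers such a change. Because compound 2 gives 0%, the step from compound 2 to compound 3 is expected to be a number 1 percentage points higher from compound 2 to compound 3 (within the scatter), that is, no change beyond the scatter. Compound 3 is therefore estimated to give 1%, with a range from 0% to 8%.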

Compound 3, a percentage reported as inhibition, at one concentration (the size of the read-out at that concentration, not a potency): 9.9%
Compound 3: the middle estimate sits 8.9 percentage points below what was measured, outside the stated range (above it).
By their numbers in this assay, from the lowest: compounds 2, 1 and 3 (each within the scatter of the next).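

In this assay, within the data shown here, the swap of fluoro for hydrogen on an aromatic carbon can now be read directly for the first time: a number 9.9 percentage points higher from compound 2 to compound 3 (within the scatter). This step lies within the scatter, so these data cannot separate hydrogen from fluoro at this position, even though the number for compound 3 looks higher at first sight. No measured evidence here bears on this step.

Going by these compounds, it remains open whether a clearly different group on the same aromatic carbon, such as an amine, a carboxylic acid or a methoxy group, would move the number beyond the scatter. On these data alone, it is also open whether the same swap of fluoro for hydrogen would give a larger step on another carbon of the ring.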